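The source may hold more compounds than are shown below. What is called first, only, known or untested is meant among the compounds shown, and "the series" means these compounds.

Of the compounds shown here, three have been measured so far in an assay for binding affinity to protein lin-28 homolog A (Mus musculus), with a stated time of 1 h; a higher number here means a weaker inhibitor, a lower number a stronger inhibitor. Compound 1 `O=S(=O)(Nc1ccccc1NS(=O)(=O)c1ccc(Cl)cc1)c1ccc(F)cc1` gives 27300 nM, compound 2 `O=S(=O)(Nc1ccccc1NS(=O)(=O)c1ccc(Cl)cc1)c1ccc(Cl)cc1` gives 27500 nM, and compound 3 `Cc1ccc(NS(=O)(=O)c2ccccc2)c(NS(=O)(=O)c2ccccc2)c1` gives 28800 nM. Compound 2 thus stands among three numbers that all lie within the usual scatter of one another; none can be told apart from the others on this evidence.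

Among the measured compounds shown here, the only step between measured compounds is a 1.0-fold higher number from compound 1 to compound 2 (0.00 log units; within the scatter), a chloro in place of fluoro on an aromatic carbon that left the number essentially unchanged. Compound 4 `Cc1ccc(NS(=O)(=O)c2ccc(Cl)cc2)c(NS(=O)(=O)c2ccc(Cl)cc2)c1` differs from compound 2 by methyl in place of hydrogen on an aromatic carbon. For the measured compounds named here, no measured pair isolates this exact change. Compound 3 carries the same methyl on its shared core, and its value and that of compound 2 fall within the scatter of each other, although the two also differ elsewhere, so that comparison is only indirect.

On this basis the step from compound 2 to compound 4 in this assay is expected to be a 1.0-fold higher number from compound 2 to compound 4 (0.01 log units; within the scatter), that is, nothing beyond the scatter. Compound 4 is therefore estimated at 28000 nM, with a likely range from 14000 nM to 56000 nM.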

Compound 4, half-maximal inhibitory concentration: 28400 nM
Compound 4: middle estimate off by 1.0-fold (0.01 log units), on the low side; the measured number falls inside the stated range.
By their numbers in this assay, from the lowest: compounds 1, 2, 4 and 3 (each within the scatter of the next).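

The direct pair now isolates the methyl: in this assay the step (a 1.0-fold higher number from compound 2 to compound 4 (0.01 log units; within the scatter)) shows that methyl in place of hydrogen on this aromatic carbon, meta to a large group and para to a large group, changes nothing that can be told from the scatter. Until now this change could be judged only indirectly through compound 3, which also differs elsewhere, whereas compound 2 and compound 4 differ in this one place alone. No measurement at hand offers an explanation for this result.

The compounds shown compare only hydrogen and methyl at this position, so it remains open whether an amine, a carboxylic acid or a longer chain there would move the number beyond the scatter. They also leave open whether any change elsewhere on the shared core would do so.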